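Replacing a Styryl Arm with a Chlorophenyl Ring

A few compounds are considered here, and "the series" means these few. Any claim that something is new, unique, unknown or untested is made for them only; others in the source may bear on it.

Compound 1 `COC(=O)/C=C/c1cccc(N(Cc2ccc(/C=C/c3cccc(C(F)(F)F)c3)cc2)C(=O)C(C)C)c1` gives 267 nM in an assay on isolated protein with Bile acid receptor (Homo sapiens) as the target; on this read-out lower numbers stand for an effect already at smaller amounts and higher numbers for an effect only at larger amounts of compound.
Compound 2 `COC(=O)/C=C/c1cccc(N(Cc2ccc(/C=C/c3cccc(C(F)(F)F)c3)cc2)C(=O)NC(C)C)c1` gives 932 nM in this assay.
Compound 3 `COC(=O)/C=C/c1cccc(N(Cc2ccc(/C=C/c3ccccn3)cc2)C(=O)C(C)C)c1` gives 310 nM in this assay.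

Compound 2 stands highest of the three, with compound 3 nearest and compound 1 furthest, both beyond the scatter, so compound 2 is the weakest binder of this set. Compound 4 `COC(=O)/C=C/c1cccc(N(Cc2ccc(-c3cccc(Cl)c3)cc2)C(=O)NC(C)C)c1` keeps the isopropylamino carbonyl of compound 2 but differs elsewhere: 3-chlorophenyl in place of 2-(3-(trifluoromethyl)phenyl)ethenyl on an aromatic carbon. Among the compounds with values here, no measured step makes a change of this kind. The closest comparison is a 1.2-fold higher number from compound 1 to compound 3 (0.06 log units; within the scatter), where the ring on the double-bonded chain carbon was exchanged with no effect beyond scatter; the step of a 3.5-fold higher number from compound 1 to compound 2 (0.54 log units; beyond the scatter) concerns the carbonyl substituent and does not bear here. Because a 1.2-fold higher number from compound 1 to compound 3 (0.06 log units; within the scatter) was small, only a modest change is expected, a 1.6-fold higher number from compound 2 to compound 4 (0.21 log units; within the scatter), with wide uncertainty. Compound 4 is estimated at 1500 nM, within 400 nM to 6000 nM.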

Compound 4, half-maximal effective concentration: 1400 nM
Estimate against measurement, compound 4: 1.1-fold (0.03 log units) above, within the range that was stated.
By their numbers in this assay, from the lowest: compounds 1 and 3 (each within the scatter of the next); then compounds 2 and 4 (each within the scatter of the next).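

In this assay, putting 3-chlorophenyl in place of 2-(3-(trifluoromethyl)phenyl)ethenyl gives a 1.5-fold higher number from compound 2 to compound 4 (0.18 log units; within the scatter). The earlier compounds shown here changed only the ring at the end of the arm, whereas here the double bond goes too and the arm is smaller, yet the number stays within the scatter. No measurement here explains this result.

Going by these compounds, it remains open whether the same swap would hold with the isopropyl carbonyl of compound 1. A simple amine or a carboxylic acid on the 3-chlorophenyl ring also remains untested in the compounds shown.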